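Hydrazone acids: aryl substituent changes and whole-organism inhibition

A few compounds are considered here, and "the series" means these few. Any claim that something is new, unique, unknown or untested is made for them only; others in the source may bear on it.

Measured compounds:
compound 1 `O=C(O)c1cnc2n(c1=O)CCC/C2=N\Nc1ccccc1`, 31.6 umol/kg
compound 2 `CC1CC/C(=N\Nc2ccccc2F)c2ncc(C(=O)O)c(=O)n21`, 5 umol/kg
compound 3 `CC1CC/C(=N\Nc2ccc(Br)cc2)c2ncc(C(=O)O)c(=O)n21`, 0.8 umol/kg

In a functional assay on the whole organism for inhibition, with Rattus norvegicus as the target (on this read-out lower numbers stand for an effect already at smaller amounts and higher numbers for an effect only at larger amounts of compound), compound 1 gives 31.6 umol/kg. Compound 2 gives 5 umol/kg, and compound 3 gives 0.8 umol/kg, the lowest number of the three; its nearest neighbour is compound 2 and its furthest compound 1, both well beyond the scatter. Among the measured compounds shown here, the one single-point step within the measured set is a 6.3-fold lower number from compound 2 to compound 3 (0.80 log units; beyond the scatter), which shows that the substituent on the phenyl ring moves the number by a worthwhile margin.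

Compound 4 `CC1CC/C(=N\Nc2ccc(CC(=O)O)cc2)c2ncc(C(=O)O)c(=O)n21` differs from compound 3 by carboxymethyl in place of bromo on an aromatic carbon. For the measured compounds named here, no measured step involves a carboxymethyl group, so the step from compound 2 to compound 3 is the only guide, and it speaks only to the size a change at this aromatic carbon can have, not to its direction here. A return toward the numbers of compound 2 and compound 1 is the expectation, so in this assay a higher number for compound 4 is expected, a 10-fold higher number from compound 3 to compound 4 (1.00 log units; beyond the scatter), with wide uncertainty. Compound 4 is estimated at 8 umol/kg, within the range 1.5 umol/kg to 40 umol/kg.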

Compound 4, dose for 50% inhibition: 60.9 umol/kg
For compound 4 the middle estimate is 7.6-fold (0.88 log units) below the measured one; the measured number lies above the stated range.
By their numbers in this assay, from the lowest: compound 3; then compound 2; then compounds 1 and 4 (each within the scatter of the next).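

In this assay, carboxymethyl in place of bromo on the same aromatic carbon, para to a large group, gives a 76-fold higher number from compound 3 to compound 4 (1.88 log units; beyond the scatter) and so reverses the direction seen in the earlier step, a 6.3-fold lower number from compound 2 to compound 3 (0.80 log units; beyond the scatter), while exceeding it in size. This aromatic carbon therefore does not merely allow further gains: a single exchange here can take away all of the advantage held by compound 3, so the low number of compound 3 depends closely on the group at this place. The exchange replaces one heavy atom with four and adds a hydrogen-bond donor and a hydrogen-bond acceptor, but nothing available here bears on which of these differences, if any, lies behind the rise.

The pair leaves size and the carboxylic acid of the side chain tied together, so the methyl ester of the same side chain and a propyl group, with a similar chain but no acid, are the obvious comparisons. From the compounds shown here alone, whether chloro or methyl at this aromatic carbon would hold the number of compound 3 also stays open.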